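The source may report more compounds than this note shows. Statements on the series, on what has been measured and on what is new or still open speak of the compounds shown alone.

In an assay on isolated protein (strain Sprague-Dawley) for inhibition of Amine oxidase [flavin-containing] B (Rattus norvegicus), read by spectrophotometry, with a stated time of 5 min (a higher number here means a weaker inhibitor, a lower number a stronger inhibitor), compound 3 `O=c1cc(CO)c2ccc(OCc3cccc(Cl)c3)cc2o1` gives 5.25 nM, the lowest number of the three measured compounds. Compound 1 `O=c1cc(Cl)c2ccc(OCc3cccc(Cl)c3)cc2o1` gives 20.9 nM in this assay, and compound 2 `O=c1cc(Oc2ccccc2)c2ccc(OCc3cccc(Cl)c3)cc2o1` gives 4070 nM. Compound 4 `CC(=O)c1cc(=O)oc2cc(OCc3cccc(Cl)c3)ccc12` differs from compound 3 by acetyl in place of hydroxymethyl on an aromatic carbon. Three measured steps at this position bear on the change: a 4.0-fold lower number from compound 1 to compound 3 (0.60 log units; beyond the scatter), a 190-fold higher number from compound 1 to compound 2 (2.29 log units; beyond the scatter), and a 780-fold lower number from compound 2 to compound 3 (2.89 log units; beyond the scatter). Chloro and hydroxymethyl, both groups of few heavy atoms, lie within a modest span of each other, and only the phenoxy of compound 2 gives a large step upward. Acetyl brings three heavy atoms and keeps one acceptor, so only a small step is expected here. Compound 4 is expected to give 15 nM in this assay, between 4 nM and 60 nM. The expected step is a 2.9-fold higher number from compound 3 to compound 4 (0.46 log units; beyond the scatter), close to the scatter.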

Compound 4, half-maximal inhibitory concentration: 39.8 nM
For compound 4 the middle estimate is 2.7-fold (0.42 log units) below the measured one; measured number inside the range.
By their numbers in this assay, from the lowest: compound 3; then compounds 1 and 4 (each within the scatter of the next); then compound 2.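

In this assay, acetyl shows that this aromatic carbon can carry a group with a double bond outside aromatic rings without the large loss seen with phenoxy (a 100-fold lower number from compound 2 to compound 4 (2.01 log units; beyond the scatter)). Losing the hydroxymethyl still counts, however (a 7.6-fold higher number from compound 3 to compound 4 (0.88 log units; beyond the scatter)), while acetyl and chloro stand level (a 1.9-fold higher number from compound 1 to compound 4 (0.28 log units; within the scatter)). Nothing measured here explains the gap between hydroxymethyl and acetyl. As far as these compounds go, whether that gap follows the hydrogen-bond donor that acetyl lacks or the larger group stays open. So does how an amine, a carboxylic acid or a longer chain would read at this place.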